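Cytotoxicity notes: 4-methylphenyl to 2-methylphenyl

The source may report more compounds than this note shows. Statements on the series, on what has been measured and on what is new or still open speak of the compounds shown alone.

In a functional assay on KB cells (Homo sapiens) for cytotoxicity (a higher number here means a weaker inhibitor, a lower number a stronger inhibitor), compound 1 `Cc1ccc(Cn2cc(C#N)c3c(N)ncnc32)cc1` gives only an assay limit, > 100000 nM. Compound 2 `CC(C)(C)c1ccc(Cn2cc(C#N)c3c(N)ncnc32)cc1` gives 3000 nM. Compound 3 `Cc1ccc(Cn2cc(C(=N)S)c3c(N)ncnc32)cc1` gives 65000 nM, the higher of the two actual numbers in this assay. The value for compound 1 is a limit and not a number.

The next structure is compound 4 `Cc1ccccc1Cn1cc(C(=N)S)c2c(N)ncnc21`. The change is 2-methylphenyl in place of 4-methylphenyl on a saturated chain carbon bound to an aromatic nitrogen.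

Two measured steps are available. The first, an at least 33-fold lower number from compound 1 to compound 2 (1.52 log units; beyond the scatter), is large and comes from tert-butyl in place of methyl on an aromatic carbon. It shows that this assay can respond strongly to a change in this part of the series, but it replaces the group and does not move it. The second, an at least 1.5-fold lower number from compound 1 to compound 3 (0.18 log units; that floor lies within the scatter), has a floor within the scatter and involves a different part of the molecule. Among the measured compounds shown here, no measured step moves a methyl group, so neither gives a direct size for this change.

A small change is therefore expected, with no shift beyond the scatter and no firm direction. The expected step is a 1.1-fold lower number from compound 3 to compound 4 (0.03 log units; within the scatter). For compound 4 the estimated value is 60000 nM, with an expected range of 20000 nM to 100000 nM.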

Compound 4, half-maximal inhibitory concentration: > 17000 nM
Compound 4 gave a limit, no number; the forecaster's own chance of this, stated with the estimate: 25%; the middle value lies beyond the limit too.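

Compound 4 gives only a limit in this assay, > 17000 nM, and not a number, so the step from compound 3 to compound 4 cannot be read. The compounds shown leave open whether 2-methylphenyl in place of 4-methylphenyl on a saturated chain carbon bound to an aromatic nitrogen shifts the number in this assay, and in which direction.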